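Swapping the group on the nitrogen of compound 3

The source may hold more compounds than are shown below. What is called first, only, known or untested is meant among the compounds shown, and "the series" means these compounds.

Measured so far in a functional assay on HCT-116 cells (Homo sapiens) for antiproliferative activity, read by MTT assay, with a stated time of 48 h; a higher number here means a weaker inhibitor, a lower number a stronger inhibitor
compound 1 `COc1ccc(-c2c(Nc3cc(OC)c(OC)c(OC)c3)c3ccccc3oc2=O)cc1` gives 63500 nM
compound 2 `COc1ccc(-c2c(Nc3ccc(C)cc3)c3ccccc3oc2=O)cc1` gives 64800 nM
compound 3 `CCOc1ccc(Nc2c(-c3ccc(OC)cc3)c(=O)oc3cc(OC)ccc23)cc1` gives 33000 nM

In this assay compound 3 gives 33000 nM and so sits within the usual scatter of both compound 1 and compound 2. These three compounds therefore cannot be put in a reliable order.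

The next compound to be tested is compound 4 `COc1ccc(-c2c(Nc3cccc(C(F)(F)F)c3)c3ccc(OC)cc3oc2=O)cc1`. Compared with compound 3, it has 3-(trifluoromethyl)phenyl in place of 4-ethoxyphenyl on a nitrogen on an aromatic ring, and the rest of the structure stays the same.

Among the compounds with values here, no measured pair shows this exact swap, so any expectation here is rough. The nearest hint is that compound 1 at 63500 nM and compound 2 at 64800 nM carry different groups on that nitrogen, yet their values lie within the scatter of each other. On this slim evidence, the expected size of a 1.1-fold higher number from compound 3 to compound 4 (0.03 log units; within the scatter) stays within the scatter, with neither direction favoured. The estimate for compound 4 is 35000 nM (expected range 15000 nM to 80000 nM).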

Compound 4, half-maximal inhibitory concentration: 41200 nM
Estimate against measurement, compound 4: 1.2-fold (0.07 log units) below; low and high end bracket the measured number.
By their numbers in this assay, from the lowest: compounds 3, 4, 1 and 2 (each within the scatter of the next).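

In this assay the swap on this nitrogen gives a 1.2-fold higher number from compound 3 to compound 4 (0.10 log units; within the scatter) and so does not separate the two groups. Within the data shown here, this is the first pair here that differs in one place only, which makes it a direct test of the group on a nitrogen on an aromatic ring, with the rest of the structure held constant. The 4-ethoxyphenyl group carries a hydrogen-bond acceptor and the 3-(trifluoromethyl)phenyl group carries none, yet this pair shows no readable difference, and no measurement available here indicates what lies behind that result.

Going by these compounds, this single swap changes both the substituent on the phenyl ring and where it sits, so the effect of each alone remains open. It is also unknown whether a different kind of group, such as a carboxylic acid or an amine on that phenyl ring, or a plain alkyl chain in place of the ring on the nitrogen, would move the number beyond the usual scatter.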